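The source may report more compounds than this note shows. Statements on the series, on what has been measured and on what is new or still open speak of the compounds shown alone.

an assay on CHO cells for binding affinity to metabotropic glutamate receptor 2 (Rattus norvegicus) (on this read-out higher numbers stand for weaker inhibition and lower numbers for stronger inhibition), has been run on two compounds built on one shared core. Compound 1 `Nc1cccc(CO[C@@H]2C[C@@H]3[C@H]([C@]2(N)C(=O)O)[C@@]3(F)C(=O)O)c1` gives 15.4 nM. Compound 2 `N[C@]1(C(=O)O)[C@H]2[C@@H](C[C@H]1OCc1cccc(F)c1F)[C@]2(F)C(=O)O` gives 4.25 nM, and the step of a 3.6-fold lower number from compound 1 to compound 2 (0.56 log units; beyond the scatter). Compound 2 therefore holds the lowest number of the two. Compound 3 `N[C@]1(C(=O)O)[C@H]2[C@@H](C[C@H]1OCc1cc(F)ccc1F)[C@]2(F)C(=O)O` differs from compound 2 by 2,5-difluorophenyl in place of 2,3-difluorophenyl on a saturated chain carbon bound to an oxygen on a saturated carbon. Among the compounds with values here, the only measured step, a 3.6-fold lower number from compound 1 to compound 2 (0.56 log units; beyond the scatter), replaced an aminophenyl with a difluorophenyl rather than rearranging fluorines on the same ring, so it gives little guidance; a step of no size beyond the scatter is expected, a 1.2-fold higher number from compound 2 to compound 3 (0.07 log units; within the scatter). For compound 3 the estimate is 5 nM, within 2 nM to 13 nM.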

Compound 3, inhibition constant: 14.4 nM
For compound 3 the middle estimate is 2.9-fold (0.46 log units) below the measured one; measured number above the stated range.
By their numbers in this assay, from the lowest: compound 2; then compounds 3 and 1 (each within the scatter of the next).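

At this position, the arrangement of the fluorines on the ring matters: with the same atoms joined differently, the change gives a 3.4-fold higher number from compound 2 to compound 3 (0.53 log units; beyond the scatter) in this assay. Two fluorines alone therefore do not secure the lower number of compound 2, and the comparison of the other pair gives a 1.1-fold lower number from compound 1 to compound 3 (0.03 log units; within the scatter) with the 2,5-difluorophenyl and 3-aminophenyl groups not separated by this read-out. No available evidence explains the difference between the two fluorine patterns. Still open, as far as these compounds go, is how a plain phenyl group or a monofluorophenyl group would compare on this same carbon.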